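The compounds below may be only part of what the source reports. "The series", "measured", "known", "first", "only" and "open" are said of these compounds alone.

Measured compounds:
compound 1, `c1ccc2c(c1)CN[C@@H](CN(CCCCNC1CCSCC1)[C@H]1CCCc3cccnc31)C2`: 54.7 nM
compound 2, `FC1(F)CCC(NC/C=C/CN(C[C@H]2Cc3ccccc3CN2)[C@H]2CCCc3cccnc32)CC1`: 82.1 nM

In a functional assay on cells for antagonist activity at C-X-C chemokine receptor type 4 (Homo sapiens), read by fluorescence and calcium flux, with stated times of 25 min and 90 s (a higher number here means a weaker inhibitor, a lower number a stronger inhibitor), compound 2 gives 82.1 nM and compound 1 gives 54.7 nM; the gap between them lies within the scatter of repeated measurements, so neither can be called the stronger inhibitor, and compound 2 simply sits alongside compound 1 on the shared core.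

Compound 3, `C(=C/CN(C[C@H]1Cc2ccccc2CN1)[C@H]1CCCc2cccnc21)\CNCc1cccnc1`, differs from compound 2 in one place: (pyridin-3-yl)methyl in place of 4,4-difluorocyclohexyl on an amine nitrogen. Going by the values given here, no pair of measured compounds shows what this kind of exchange does, so there is no measured step to lean on. With the two measured compounds sitting close together, a small step is expected, with no strong reason to expect one direction over the other beyond the scatter. The step from compound 2 to compound 3 is expected to be a 1.2-fold higher number from compound 2 to compound 3 (0.09 log units; within the scatter) in this assay. Compound 3 is estimated at 100 nM in this assay, with a range from 35 nM to 300 nM.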

Compound 3, half-maximal inhibitory concentration: 92.8 nM
The estimate for compound 3 lay 1.1-fold (0.03 log units) above the measured number, and the stated range covers the measured number.
By their numbers in this assay, from the lowest: compounds 1, 2 and 3 (each within the scatter of the next).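

In this assay, putting (pyridin-3-yl)methyl in place of 4,4-difluorocyclohexyl on an amine nitrogen gives a 1.1-fold higher number from compound 2 to compound 3 (0.05 log units; within the scatter), so at this position an aromatic ring holding a ring nitrogen and a saturated ring carrying two fluorines cannot be told apart. The wider exchange, which replaces the whole sulfur-containing group of compound 1 on a saturated chain carbon bound to an amine nitrogen, gives a 1.7-fold higher number from compound 1 to compound 3 (0.23 log units; within the scatter), so these two compounds cannot be told apart in this assay either. Nothing measured here gives a reason for this tolerance.

Going by these compounds, whether the ring nitrogen of the pyridine matters remains open, since a plain benzyl group would be needed to test it. On these data alone, it is also open whether a carboxylic acid or a small methyl group on this amine nitrogen would give a similar number.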